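Furan in place of fluorophenyl on the amide-side branch

The source may report more compounds than this note shows. Statements on the series, on what has been measured and on what is new or still open speak of the compounds shown alone.

Measured so far:
compound 1 `Cc1nc(N)sc1CCCN/C(N)=N/C(=O)NC(C)c1cccc(F)c1` — 64.6 nM
compound 2 `Cc1nc(N)sc1CCCN/C(N)=N/C(=O)NC(c1ccccc1)c1ccccc1` — 331 nM

Both compounds share a core and differ only in the group on the saturated chain carbon bound to the amide-type nitrogen. In a functional assay on HEK293T cells for agonist activity at histamine H2 receptor (Homo sapiens), read by beta-arrestin recruitment (a higher number here means that more compound is needed for the effect, a lower number that less compound is needed), compound 1 gives 64.6 nM, the lowest of the two numbers recorded. Compound 2 gives 331 nM in this assay, a higher number that lies beyond the usual scatter, so compound 1 is the more potent of the pair on the numbers shown.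

Compound 3 `Cc1nc(N)sc1CCCN/C(N)=N/C(=O)NC(C)c1ccco1` is not yet measured. It differs from compound 1 in one place: furan-2-yl in place of 3-fluorophenyl on a saturated chain carbon bound to an amide-type nitrogen and a saturated chain carbon. Among the measured compounds shown here, no step between two measured compounds corresponds to this change, so the expectation rests on compound 1 alone. A small shift toward a higher number is expected, of the order a 1.9-fold higher number from compound 1 to compound 3 (0.27 log units; within the scatter), possibly still within the scatter. Compound 3 is therefore estimated at 120 nM in this assay, with a range from 40 nM to 400 nM.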

Compound 3, half-maximal effective concentration: 234 nM
The estimate for compound 3 lay 2.0-fold (0.29 log units) below the measured number; low and high end bracket the measured number.
By their numbers in this assay, from the lowest: compound 1; then compounds 3 and 2 (each within the scatter of the next).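

In this assay, furan-2-yl in place of 3-fluorophenyl on the saturated chain carbon bound to an amide-type nitrogen and a saturated chain carbon gives a 3.6-fold higher number from compound 1 to compound 3 (0.56 log units; beyond the scatter). This single-place step shows that the two aromatic rings are not interchangeable at this position, although the exchange costs only a modest step and compound 3 still gives 234 nM. No measurement at hand gives a reason for the step.

The compounds shown do not separate the contributions of ring size, the ring oxygen and the fluorine, and unsubstituted phenyl or thiophen-2-yl at the same carbon would help to tell these apart. Also open, from the compounds shown here alone, is how a nitrogen-containing ring such as pyridin-2-yl would compare with compound 1 in this position.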